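The source may report more compounds than this note shows. Statements on the series, on what has been measured and on what is new or still open speak of the compounds shown alone.

Going by the values given here, in an assay for inhibition of alkaline phosphatase, tissue-nonspecific isozyme (Homo sapiens), read by spectrophotometry, with stated times of 10 min and 20 min (on this read-out higher numbers stand for weaker inhibition and lower numbers for stronger inhibition), compound 3 `O=C1/C(=C/c2cccc(F)c2)NS(=O)(=O)c2ccccc21` gives 3190 nM, the highest number among the three compounds measured so far. Compound 1 `COc1ccccc1/C=C1\NS(=O)(=O)c2ccccc2C1=O` comes closest to it with 2590 nM, a gap that lies within the usual scatter of this kind of measurement. Compound 2 `O=C1/C(=C/c2ccc(Cl)cc2)NS(=O)(=O)c2ccccc21` stands furthest from it with 250 nM. The only single-change step among these three is a 13-fold higher number from compound 2 to compound 3 (1.11 log units; beyond the scatter), which shows that swapping one substituted phenyl ring for another at this place can shift the number a long way. Compound 4 `Cc1ccccc1/C=C1\NS(=O)(=O)c2ccccc2C1=O` differs from compound 3 by 2-methylphenyl in place of 3-fluorophenyl on a double-bonded chain carbon bound to a double-bonded ring carbon. Among the compounds with values here, no measured step covers this exact exchange; the nearest guide is compound 1, which carries a different group at the same place and sits within the scatter of compound 3. Compound 4 is therefore expected to stay close to compound 3, with an estimated step of a 1.3-fold lower number from compound 3 to compound 4 (0.11 log units; within the scatter) that is unlikely to exceed the scatter. The estimate for compound 4 in this assay is 2500 nM, with a range from 900 nM to 7000 nM.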

Compound 4, half-maximal inhibitory concentration: 2360 nM
Beside the measured number, compound 4's estimate is 1.1-fold (0.03 log units) above it; low and high end bracket the measured number.
By their numbers in this assay, from the lowest: compound 2; then compounds 4, 1 and 3 (each within the scatter of the next).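

In this assay putting 2-methylphenyl in place of 3-fluorophenyl gives a 1.4-fold lower number from compound 3 to compound 4 (0.13 log units; within the scatter) and so these two rings cannot be told apart on a double-bonded chain carbon bound to a double-bonded ring carbon. Methyl in place of methoxy on an aromatic carbon gives a 1.1-fold lower number from compound 1 to compound 4 (0.04 log units; within the scatter) and this swap on the ring also leaves the number unchanged within the scatter. Against these, 2-methylphenyl in place of 4-chlorophenyl gives a 9.4-fold higher number from compound 2 to compound 4 (0.97 log units; beyond the scatter) and this shows a second ring, besides 3-fluorophenyl, that sits well apart from 4-chlorophenyl.

No evidence at hand accounts for this separation. The compounds shown leave open whether the chlorine itself or the place it occupies on the ring sets compound 2 apart, and how a ring carrying an amine or a carboxylic acid would read.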